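The source may hold more compounds than are shown below. What is called first, only, known or untested is meant among the compounds shown, and "the series" means these compounds.

Working notes on the series

Three analogues sharing one core have been measured in a functional assay on MDA-MB-231 cells (Homo sapiens) for antiproliferative activity, read by MTT assay, with a stated time of 72 h; a higher number here means a weaker inhibitor, a lower number a stronger inhibitor. Compound 1 `O=S1(=O)C=Cc2ccc(Nc3ccc(C(F)(F)F)cc3)cc21` gives 1300 nM; compound 2 `COc1ccc(Nc2ccc3c(c2)S(=O)(=O)C=C3)cc1` gives 1400 nM; compound 3 `COc1ccccc1Nc1cccc2c1S(=O)(=O)C=C2` gives 2400 nM. The difference between the cores of compound 2 and compound 3 is not broken down here. Between compound 2 and compound 1 the change is trifluoromethyl in place of methoxy on an aromatic carbon, and in this assay it made a 1.1-fold lower number from compound 2 to compound 1 (0.03 log units; within the scatter).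

Compound 4 `O=S1(=O)C=Cc2cccc(Nc3ccccc3C(F)(F)F)c21` is not yet measured. Its change from compound 3 is trifluoromethyl in place of methoxy on an aromatic carbon, the same kind of change as that from compound 2 to compound 1, but here the place is ortho to a large group rather than para to a large group. Resting on the step from compound 2 to compound 1 in this assay, compound 4 is expected to sit close to compound 3, with a step of about a 1.1-fold lower number from compound 3 to compound 4 (0.04 log units; within the scatter). The estimate for compound 4 in this assay is 2200 nM, between 1000 nM and 5000 nM.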

Compound 4, half-maximal inhibitory concentration: 3900 nM
Compound 4: the middle estimate sits 1.8-fold (0.25 log units) below what was measured; the measured number falls inside the stated range.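

In this assay, trifluoromethyl in place of methoxy on an aromatic carbon gives a 1.6-fold higher number from compound 3 to compound 4 (0.21 log units; within the scatter), and the two steps for this change do not differ: the same change on two cores in this assay, a 1.1-fold lower number (0.03 log units; within the scatter) from compound 2 to compound 1 and a 1.6-fold higher number (0.21 log units; within the scatter) from compound 3 to compound 4, 1.8-fold (0.24 log units) apart, within the scatter of two such steps. On these two cores, then, the change carries over with no step beyond the scatter, including where the place is ortho to a large group in compound 4. This does not show that the change is neutral on other cores, and two small steps cannot separate a slight real shift from scatter.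

The compounds shown leave open whether another group at this place, such as an amine, a carboxylic acid or a nitrile, would give a step beyond the scatter.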